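The source may report more compounds than this note shows. Statements on the series, on what has been measured and on what is new or still open speak of the compounds shown alone.

Measured compounds:
compound 1 `Cc1ccc(S(=O)(=O)N2N=C(c3ccc(N4CCN(C)CC4)cc3)CC2c2ccc(N(C)C)cc2)cc1`, 32.2%
compound 2 `CN1CCN(c2ccc(C3=NN(S(=O)(=O)c4ccc(Br)cc4)C(c4ccc(N(C)C)cc4)C3)cc2)CC1`, 87.1%
compound 3 `CC(=O)N1N=C(c2ccc(-n3cncn3)cc2)CC1c1ccc(N(C)C)cc1`, 11%

In a functional assay on HCC1806 cells (Homo sapiens) for inhibition, read by sulforhodamine B assay, tested at 10 uM (on this read-out higher numbers stand for more inhibition at the one concentration tested (going by the name of the read-out) and lower numbers for less inhibition), compound 3 gives 11%, the lowest of the three numbers; compound 1 sits above it by a gap beyond the scatter, and compound 2 is higher still. Compound 4 `CN(C)c1ccc(C2CC(c3ccc(-n4cncn4)cc3)=NN2S(=O)(=O)c2ccc(C#N)cc2)cc1` has not yet been measured. It differs from compound 3 in one place: (4-cyanophenyl)sulfonyl in place of acetyl on an amine nitrogen in a ring. For the measured compounds named here, no measured step covers this exchange directly. Going by the values given here, the single step on record, a number 54.9 percentage points higher from compound 1 to compound 2 (beyond the scatter), concerns a different place, the substituent on the sulfonyl-bearing aromatic ring, yet it shows that the identity of that ring can move this assay strongly. Both compounds carrying an arylsulfonyl group in this set, compound 1 and compound 2, give numbers well above compound 3, which carries acetyl, although they also differ from compound 3 elsewhere. A rise in this assay is therefore expected, of about a number 39 percentage points higher from compound 3 to compound 4 (beyond the scatter), though its size is uncertain. Compound 4 is estimated at 50%, between 20% and 85%.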

Compound 4, a percentage reported as inhibition, at one concentration (the size of the read-out at that concentration, not a potency): 33.1%
Compound 4: the middle estimate sits 16.9 percentage points above what was measured; low and high end bracket the measured number.
By their numbers in this assay, from the lowest: compound 3; then compounds 1 and 4 (each within the scatter of the next); then compound 2.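

With only the group on the amine nitrogen in the ring exchanged and the rest of the molecule unchanged, this assay gives a number 22.1 percentage points higher from compound 3 to compound 4 (beyond the scatter) as the direct effect of this change. For the compounds shown here, this is the first reading of this position on its own, since the earlier arylsulfonyl compounds also differed from the acetyl compound 3 elsewhere. No measurement shown explains why the number rises.

The exchange swaps several features at once, namely the sulfonyl link, the aromatic ring and its nitrile, so the compounds shown do not tell which of these carries the rise. Methanesulfonyl, which keeps the sulfonyl without the ring, and benzoyl, which keeps a ring on a carbonyl, would help separate these parts at this position.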